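Swapping the sulfonyl substituent of compound 1 for a new aryl group

The source may hold more compounds than are shown below. What is called first, only, known or untested is meant among the compounds shown, and "the series" means these compounds.

Compound 1: `CCCS(=O)(=O)NC(=O)c1cc(COc2ccc(-c3ccc(OC)cc3)cc2)c(C)o1`, 5 nM
Compound 2: `Cc1oc(CCC(=O)O)cc1COc1ccc(-c2ccccc2)cc1`, 80 nM
Compound 3: `O=C(O)c1cc(COc2ccc(-c3ccccc3)cc2)co1`, 2000 nM

All three compounds were tested in an assay on cells for displacement of a labelled ligand from prostaglandin E2 receptor EP4 subtype (Homo sapiens), read by scintillation counting; a lower number here means a stronger inhibitor, a higher number a weaker inhibitor. On the numbers shown, compound 1 gives the lowest value of the three, and compound 2 and compound 3 both sit clearly higher, beyond the scatter of the measurement. Compound 2 and compound 3 differ from compound 1 in several places at once, so nothing more than their raw values can be read from them.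

Compound 4, `COc1ccc(-c2ccc(OCc3cc(C(=O)NS(=O)(=O)c4ccc(CN)cc4)oc3C)cc2)cc1`, has not been measured yet. It is built from compound 1 by one change: 4-(aminomethyl)phenyl in place of propyl on a sulfonyl sulfur. The other neighbour of that sulfonyl sulfur, an amide-type nitrogen, stays as it is, and the rest of the shared core is unchanged.

For the measured compounds named here, no measured pair isolates this kind of change, so its effect is not yet known from the data. The expectation is a small step for the move from compound 1 to compound 4 in this assay, a 2.4-fold higher number from compound 1 to compound 4 (0.38 log units; beyond the scatter), most likely towards a somewhat higher number, and quite possibly no step beyond the scatter. Compound 4 is therefore estimated at 12 nM, with a range from 3 nM to 50 nM.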

Compound 4, inhibition constant: 100 nM
For compound 4 the middle estimate is 8.3-fold (0.92 log units) below the measured one, and the stated range ends below it.
By their numbers in this assay, from the lowest: compound 1; then compounds 2 and 4 (each within the scatter of the next); then compound 3.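

In this assay, for the compounds shown here, the substituent on the sulfonyl sulfur proves to be a sensitive place: putting 4-(aminomethyl)phenyl in place of propyl gives a 20-fold higher number from compound 1 to compound 4 (1.30 log units; beyond the scatter), the first step in this set that isolates a single change. The position therefore does not accept every group equally, and this swap, which brings in an aromatic ring and an amine-bearing side chain together, gives up much of the strength seen with the small propyl chain. Nothing measured here explains why the step is so large.

The compounds shown leave open whether the step comes from the aromatic ring itself or from the aminomethyl group it carries, a question that a plain phenyl on the sulfonyl sulfur, with no amine, would help to separate. Also open, on these data alone, is how the number would respond to a longer chain such as pentyl in place of propyl, or to a carboxylic acid in place of the amine on the ring, so one step cannot yet describe a trend at this position.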